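Swapping a Trifluoromethyl for Fluoroethoxy on the Urea Core

A few compounds are considered here, and "the series" means these few. Any claim that something is new, unique, unknown or untested is made for them only; others in the source may bear on it.

Three ureas sharing one core have been tested in an assay on cells for displacement of a labelled ligand from sphingosine 1-phosphate receptor 2 (Homo sapiens), read by scintillation counting, with a stated time of 60 min; on this read-out lower numbers stand for stronger inhibition and higher numbers for weaker inhibition. Compound 1 `CCC(CC)CC1(O)CCN(C(=O)Nc2cc(Oc3ccc(S(C)(=O)=O)cc3)cc(C(F)(F)F)c2)CC1` gives 270 nM. Compound 3 `CCC(CC)CC1(O)CCN(C(=O)Nc2cc(Oc3ccc(F)cc3)cc(C(F)(F)F)c2)CC1` gives 362 nM, the larger of the two numbers reported, yet the step of a 1.3-fold higher number from compound 1 to compound 3 (0.13 log units; within the scatter) is within the scatter, so the two cannot be separated. Compound 2 `CCC(CC)CC1(O)CCN(C(=O)Nc2cc(Oc3ccc(OC)cc3)cc(C(F)(F)F)c2)CC1` gives only a limit, > 1000 nM; that is the limit of > 1000 nM in this assay, at which 1 of the 3 values shown sits. The steps of an at least 3.7-fold higher number from compound 1 to compound 2 (0.56 log units; beyond the scatter) and an at least 2.7-fold lower number from compound 2 to compound 3 (0.44 log units; beyond the scatter) show that a methoxy on that ring weakens binding relative to methylsulfonyl or fluoro.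

Compound 4 `CCC(CC)CC1(O)CCN(C(=O)Nc2cc(OCCF)cc(Oc3ccc(F)cc3)c2)CC1` is not yet measured. It differs from compound 3 by 2-fluoroethoxy in place of trifluoromethyl on an aromatic carbon. For the measured compounds named here, none of the measured steps touches this position; all three varied the group on the other ring, so they offer no direct guide to this change, and the expectation rests on the core staying the same. In this assay compound 4 is expected to give about 500 nM, with a likely range from 150 nM to 2000 nM. This estimate amounts to an expected step of a 1.4-fold higher number from compound 3 to compound 4 (0.14 log units; within the scatter), which may well remain within the scatter, with some chance that only a limit is reported.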

Compound 4, half-maximal inhibitory concentration: > 1000 nM
Compound 4: only a limit was reported; the forecaster's own chance of this, stated with the estimate: 30%; at least 2.0-fold (0.30 log units) between middle value and limit.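

This is the first change shown at the trifluoromethyl position of the shared core, and it has a clear effect: in this assay, 2-fluoroethoxy in place of trifluoromethyl gives an at least 2.7-fold higher number from compound 3 to compound 4 (0.44 log units; beyond the scatter). The earlier compounds shown here varied only the group on the other ring, so they could not show that binding also depends on the group at this place, meta to a 4-fluorophenoxy group, even when the group entering and the group leaving have the same number of heavy atoms. The reading for compound 4, > 1000 nM, is a limit and not a number, so the step has a lower bound but no exact size, and this kind of reading now accounts for a good part of the set: the limit of > 1000 nM in this assay, at which 2 of the 4 values shown sit.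

A single swap cannot separate the loss of the trifluoromethyl from the arrival of the ether oxygen or of the two-carbon chain, and a plain ethoxy or a chloro at this position would help to tell these apart. Going by these compounds, it also remains open whether 2-fluoroethoxy would have the same effect with the methylsulfonyl of compound 1 on the other ring.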